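Fluoro Anilino Quinone Series: Rat Aorta Inhibition Notes

The source may report more compounds than this note shows. Statements on the series, on what has been measured and on what is new or still open speak of the compounds shown alone.

Measured so far:
compound 1 `O=C1C(Nc2cccc(F)c2)=CC(=O)c2ncccc21` 805 nM
compound 2 `O=C1C(Nc2ccc(F)c(F)c2)=CC(=O)c2ncccc21` 251 nM
compound 3 `O=C1C=C(Nc2cccc(F)c2)C(=O)c2cnccc21` 562 nM

All three were run in a functional assay (aorta) for inhibition, with Rattus norvegicus as the target; on this read-out higher numbers stand for an effect only at larger amounts of compound and lower numbers for an effect already at smaller amounts. Compound 1 and compound 2 share a core; compound 3 carries the same atoms joined differently, and the difference between the two cores is not broken down here. In this assay compound 3 and compound 1 give numbers within the scatter of each other, so no order between them is claimed.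

Within the data shown here, the one counted step is a 3.2-fold lower number from compound 1 to compound 2 (0.51 log units; beyond the scatter), with the change (fluoro in place of hydrogen on an aromatic carbon).

Compound 4 `O=C1C=C(Nc2cc(F)cc(F)c2)C(=O)c2cnccc21` is not yet measured. It arises from compound 3 by fluoro in place of hydrogen on an aromatic carbon. This is the same kind of change as the step from compound 1 to compound 2, but the place differs: in compound 2 the entering fluoro is ortho to a fluoro group and para to a large group, while in compound 4 it is meta to a fluoro group and meta to a large group. Among the measured compounds shown here, because the only measured instance is a 3.2-fold lower number from compound 1 to compound 2 (0.51 log units; beyond the scatter), a lowering of the number is expected for compound 4 as well, though a somewhat smaller one given the different placement and the changed core, so the expected step is a 1.8-fold lower number from compound 3 to compound 4 (0.24 log units; within the scatter). For compound 4 in this assay the estimate is 320 nM, with a range of 120 nM to 800 nM.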

Compound 4, half-maximal effective concentration: 290 nM
Beside the measured number, compound 4's estimate is 1.1-fold (0.04 log units) above it; the measured number falls inside the stated range.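

In this assay fluoro in place of hydrogen on an aromatic carbon gives a 1.9-fold lower number from compound 3 to compound 4 (0.29 log units; within the scatter) and this step taken alone cannot be told from scatter. Set beside the earlier step, the two results do not separate, so the numbers are compatible with the change carrying over from one core to the other: the same change on two cores in this assay, a 3.2-fold lower number (0.51 log units; beyond the scatter) from compound 1 to compound 2 and a 1.9-fold lower number (0.29 log units; within the scatter) from compound 3 to compound 4, 1.7-fold (0.22 log units) apart, within the scatter of two such steps.

This does not show that the step has the same size on both cores, since each core offers a single step and the entering fluoro stands meta to a fluoro group and meta to a large group only in compound 4, so the share of core and the share of placement cannot be told apart.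

Still open, on these data alone, is how each core responds when the same fluoro pattern is compared directly on both. The compounds shown also carry only fluoro on the anilino ring, which leaves open whether chloro, methoxy, an amine or a carboxylic acid there would follow the same course on the two cores.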